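A few compounds are considered here, and "the series" means these few. Any claim that something is new, unique, unknown or untested is made for them only; others in the source may bear on it.

Measured compounds:
- compound 1 `Cn1c(=O)c(S(=O)(=O)c2ccc(F)cc2F)cc2cnc(Nc3ccc4c(c3)CC(=O)N4)nc21`: 100000 nM
- compound 2 `Cc1ccc(S(=O)(=O)c2cc3cnc(Nc4cnc5[nH]ccc5c4)nc3n(C)c2=O)cc1`: 25000 nM

In a functional assay on DU-145 cells (Homo sapiens) for inhibition, read by trypan blue exclusion, with a stated time of 72 h (a lower number here means a stronger inhibitor, a higher number a weaker inhibitor), compound 1 gives 100000 nM, the highest of the two numbers. Its nearest neighbour, compound 2, gives 25000 nM, a lower number by a margin beyond the usual scatter.

Compound 3 `Cc1cc2cc(Nc3ncc4cc(S(=O)(=O)c5ccc(F)cc5F)c(=O)n(C)c4n3)ccc2[nH]1` has not yet been measured. It differs from compound 1 in one place: a group of 10 heavy atoms (9 carbon, 1 nitrogen; one five-membered aromatic ring with 1 hetero atom, one six-membered aromatic ring of carbon only) in place of a group of 10 heavy atoms (8 carbon, 1 nitrogen, 1 oxygen; one five-membered non-aromatic ring with 1 hetero atom, one six-membered aromatic ring of carbon only), on a nitrogen on an aromatic ring. The entering group is 2-methyl-1H-indol-5-yl.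

For the measured compounds named here, no measured pair shows this change alone, since compound 2 differs from compound 1 in more than one place. Any expectation is therefore loose. A moderate step to a lower number is expected in this assay, resting only on compound 2 at 25000 nM. The estimate amounts to a 2.9-fold lower number from compound 1 to compound 3 (0.46 log units; beyond the scatter), an expected gain that may not clear the scatter by much. For compound 3 the estimated value is 35000 nM, with an expected range of 10000 nM to 100000 nM.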

Compound 3, half-maximal inhibitory concentration: 750 nM
Estimate against measurement, compound 3: 47-fold (1.67 log units) above; measured number below the stated range.
By their numbers in this assay, from the lowest: compound 3; then compound 2; then compound 1.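

In this assay, placing 2-methyl-1H-indol-5-yl on the nitrogen on an aromatic ring gives a 130-fold lower number from compound 1 to compound 3 (2.12 log units; beyond the scatter), so this position responds strongly to the group it carries. The size of the step does not follow the heavy-atom count, which is the same for both groups, and each group has one hydrogen-bond donor; they differ in that the entering group has an aromatic five-membered ring and no hydrogen-bond acceptor. The compounds shown offer nothing measured that explains the step.

The compounds shown do not separate the contribution of the 2-methyl group from that of the aromatic ring, a question that the unsubstituted 1H-indol-5-yl group or a 2-ethyl-1H-indol-5-yl group would address. From the compounds shown here alone, it also remains open whether the same change would have a comparable effect with a 4-methylphenyl group on the sulfonyl in place of the difluorophenyl group.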